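A few compounds are considered here, and "the series" means these few. Any claim that something is new, unique, unknown or untested is made for them only; others in the source may bear on it.

Measured so far in an in vitro assay on HEK293 cells for displacement of a labelled ligand from adenosine receptor A2b (Homo sapiens); on this read-out lower numbers stand for stronger inhibition and higher numbers for weaker inhibition:
compound 1, `CCCn1c(=O)c2nc(-c3cnn(Cc4cc(C(F)(F)F)ccc4Cl)c3)[nH]c2n(CCC)c1=O`, gives 22 nM;
compound 2, `CCCn1c(=O)c2nc(-c3cnn(Cc4ccc(OC)c(C(F)(F)F)c4)c3)[nH]c2n(CCC)c1=O`, gives 410 nM;
compound 3, `CCCn1c(=O)c2nc(-c3cnn(-c4ccccc4)c3C(F)(F)F)[nH]c2n(CCC)c1=O`, gives only a limit of the assay, > 6600 nM.

Compound 3 thus stands apart from the other two: its result is a limit, not a number (the limit of > 6600 nM in this assay, at which 1 of the 3 values shown sits). Compound 4, `CCCn1c(=O)c2nc(-c3cnn(-c4ccc(Cl)cc4)c3C(F)(F)F)[nH]c2n(CCC)c1=O`, differs from compound 3 in one place: chloro in place of hydrogen on an aromatic carbon. For the measured compounds named here, no step between measured compounds shows how such a change moves this assay. The shared core, the trifluoromethyl and the phenyl all remain as in compound 3, so the step from compound 3 to compound 4 is expected to stay within the scatter, or close to it: a step that the limit leaves unreadable from compound 3 to compound 4. Compound 4 is therefore expected to give about 8000 nM, in a range from 2000 nM to 30000 nM, most likely once more only a limit.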

Compound 4, inhibition constant: > 6600 nM
Compound 4 was reported as a limit; the forecaster's own chance of this, stated with the estimate: 70%; the middle value lies beyond the limit too.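

Compound 3 and compound 4 are both reported only as limits, not numbers, so no step between them can be read: the limit of > 6600 nM in this assay, at which 2 of the 4 values shown sit.

As far as these compounds go, what the change from phenyl to 4-chlorophenyl does in this assay remains open.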